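A few compounds are considered here, and "the series" means these few. Any claim that something is new, unique, unknown or untested is made for them only; others in the source may bear on it.

Series on a shared core carrying a single substituent on an aromatic carbon; tolerance of the compounds is followed in an ADME assay on Akata cells (Homo sapiens) for cytotoxicity, with a stated time of 7 days; a higher number here means that more compound is tolerated, a lower number that less compound is tolerated. Compound 1 `Nc1nc(OCC(F)(F)F)c2ncn(/C=C3/CC3(CO)CO)c2n1` carries a 2,2,2-trifluoroethoxy group. In this assay compound 1 reaches only a limit, > 20000 nM. Compound 2 `CCCSc1nc(N)nc2c1ncn2/C=C1/CC1(CO)CO` carries propylsulfanyl in its place. In this assay compound 2 likewise gives only a limit, > 20000 nM. Compound 3 `CCCNc1nc(N)nc2c1ncn2/C=C1/CC1(CO)CO` carries propylamino. In this assay compound 3 also gives only a limit, > 24000 nM. Compound 2 therefore stands at a limit, as do the two further values: two values sit at the limit of > 20000 nM in this assay, at which 2 of the 3 values shown sit, and one at the limit of > 24000 nM in this assay, at which 1 of the 3 values shown sits. The steps a step that the two limits leave unreadable from compound 1 to compound 2, a step that the two limits leave unreadable from compound 1 to compound 3 and a step that the two limits leave unreadable from compound 2 to compound 3 cannot be read for size or direction. Compound 4 `CC(C)Sc1nc(N)nc2c1ncn2/C=C1/CC1(CO)CO` differs from compound 2 by isopropyl in place of propyl on a sulfur. Among the measured compounds shown here, no measured step bears on this change, every value being a limit. For compound 4 the step expected is a number no higher from compound 2 to compound 4 (the limit leaves the size open), none beyond the scatter. Compound 4 is estimated at 20000 nM, within 10000 nM to 40000 nM, most likely once more reported as a limit.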

Compound 4, half-maximal cytotoxic concentration: > 20000 nM
Compound 4: a limit, no number; the forecaster's own chance of this, stated with the estimate: 85%; the middle value lies on the limit itself.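

In this assay compound 4 also gives only a limit, > 20000 nM, and its steps from compound 1, compound 2 and compound 3 cannot be read for size or direction. The compounds shown leave open how tolerance changes with the substituent, with most values at one limit: the limit of > 20000 nM in this assay, at which 3 of the 4 values shown sit.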